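This account rests on a few compounds, and the source may have more. Where it says the series, first, only, none or still open, it means among the compounds named here.

Working notes on the series in a functional assay on U-937 cells (Homo sapiens), read by cAMP accumulation; on this read-out lower numbers stand for an effect already at smaller amounts and higher numbers for an effect only at larger amounts of compound. Compound 1 `CCc1nn(C2CCCC2)c2c1CCN(c1ccccc1)C2=O` gives 70 nM, compound 2 `CCc1nn(C2CCCC2)c2c1CCN(c1cccc(OC)c1)C2=O` gives 330 nM and compound 3 `CCc1nn(C2CCCC2)c2c1CCN(c1ccccc1C)C2=O` gives 330 nM. Compound 2 thus stands level with compound 3, and both sit at the high end of the three numbers. Compound 4 `CCc1nn(C2CCCCC2)c2c1CCN(c1cccc(OC)c1)C2=O` differs from compound 2 on an aromatic nitrogen: cyclohexyl in place of cyclopentyl on an aromatic nitrogen. The measured steps all concern the aryl group on the amide-type nitrogen: a 4.7-fold higher number from compound 1 to compound 2 (0.67 log units; beyond the scatter), a 4.7-fold higher number from compound 1 to compound 3 (0.67 log units; beyond the scatter) and no change at the digits printed from compound 2 to compound 3 (within the scatter). None changes the cyclopentyl, so they give only a loose guide to size and none to direction. In this assay no shift beyond the scatter is expected, and the estimated step is a 1.1-fold lower number from compound 2 to compound 4 (0.04 log units; within the scatter). The estimate for compound 4 is 300 nM, with an expected range of 110 nM to 850 nM.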

Compound 4, half-maximal effective concentration: 980 nM
Estimate against measurement, compound 4: 3.3-fold (0.51 log units) below; measured number above the stated range.
By their numbers in this assay, from the lowest: compound 1; then compounds 2 and 3 (each within the scatter of the next); then compound 4.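

The group on the aromatic nitrogen also moves the number: in this assay, cyclohexyl in place of cyclopentyl gives a 3.0-fold higher number from compound 2 to compound 4 (0.47 log units; beyond the scatter), whereas all earlier steps concerned the aryl group on the amide-type nitrogen. At this place, a six-membered carbon ring is thus not interchangeable with a five-membered one. No measurement at hand bears on the reason for this step. As far as these compounds go, whether cyclobutyl or an open chain such as isopropyl at this place would give a lower number remains open, as does whether the step holds with the phenyl of compound 1.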